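A few compounds are considered here, and "the series" means these few. Any claim that something is new, unique, unknown or untested is made for them only; others in the source may bear on it.

Measured in a functional assay on L1210 cells (Mus musculus) for inhibition; on this read-out lower numbers stand for stronger inhibition and higher numbers for weaker inhibition:
- compound 1 `COc1cccc(/C=C2\CCCc3ccccc3C2=O)c1OC` gives > 500000 nM as a limit, not a number
- compound 2 `O=C1/C(=C/c2ccccc2Br)CCCc2ccccc21` gives 37000 nM as a measured value

Within the data shown here, compound 2 holds the only true number so far, and the other reading sits at the limit of > 500000 nM in this assay, at which 1 of the 2 values shown sits, of the assay.

Next is compound 3 `COc1ccccc1/C=C1\CCCc2ccccc2C1=O`, with methoxy in place of bromo on an aromatic carbon ortho to a large group. Among the measured compounds shown here, no measured step covers this change. Weaker inhibition is expected, with methoxy-bearing compound 1 at the limit > 500000 nM as the only guide. The expected move is a 2.4-fold higher number from compound 2 to compound 3 (0.39 log units; beyond the scatter) in size. Compound 3 is estimated at 90000 nM in this assay, with an expected range of 25000 nM to 350000 nM for this estimate.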

Compound 3, half-maximal inhibitory concentration: 46100 nM
Beside the measured number, compound 3's estimate is 2.0-fold (0.29 log units) above it; low and high end bracket the measured number.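

Methoxy in place of bromo on this aromatic carbon, ortho to a large group, gives a 1.2-fold higher number from compound 2 to compound 3 (0.10 log units; within the scatter) in this assay, so the two groups are not told apart here. Hydrogen in place of the further methoxy of compound 1 gives an at least 10-fold lower number from compound 1 to compound 3 (1.03 log units; beyond the scatter), so the large gap goes with that further methoxy and not with the methoxy shared with compound 3. The reading of compound 1 is a limit, not a number: the limit of > 500000 nM in this assay, at which 1 of the 3 values shown sits.

On these data alone, whether an amine or a carboxylic acid on this aromatic carbon would keep the same level stays open. Also open, as far as these compounds go, is how the series reads with plain hydrogen there.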